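This account rests on a few compounds, and the source may have more. Where it says the series, first, only, none or still open, it means among the compounds named here.

Compound 3 `COc1ccc(-c2nc(CNC(=O)CSC)sc2-c2ccc(OC)cc2)cc1` is known in a functional assay with Oryctolagus cuniculus as the target (on this read-out higher numbers stand for weaker inhibition and lower numbers for stronger inhibition), only by a limit: compound 3 gives < 100 nM. Among the compounds with values here, compound 2 `COc1ccc(-c2nc(CNC(C)=O)sc2-c2ccc(OC)cc2)cc1` carries the one plain number in this set, as compound 2 gives 15 nM. Compound 1 `COc1ccc(-c2nc(/N=C(\N)N3CCOCC3)sc2-c2ccc(OC)cc2)cc1` again sits at a limit, since compound 1 gives < 1000 nM. Compound 4 `COc1ccc(-c2nc(C(=O)N3CCOCC3)sc2-c2ccc(OC)cc2)cc1` has not been measured; it differs from compound 3 by (morpholin-4-yl)carbonyl in place of ((((methylsulfanyl)methyl)carbonyl)amino)methyl on an aromatic carbon. Within the data shown here, no measured step covers this change. The steps a step that the limit leaves unreadable from compound 2 to compound 3 and a step that the two limits leave unreadable from compound 1 to compound 3 cannot be sized because of the limit of < 100 nM in this assay, at which 1 of the 3 values shown sits, and a step that the limit leaves unreadable from compound 1 to compound 2 cannot be sized because of the limit of < 1000 nM in this assay, at which 1 of the 3 values shown sits. Compound 4 is therefore expected near 100 nM, within 20 nM to 600 nM. The step this estimate implies, a number no lower from compound 3 to compound 4 (the limit leaves the size open), is expected to stay within the scatter.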

Compound 4, half-maximal inhibitory concentration: < 10 nM
Compound 4: no number, only a limit (the forecaster's own chance of this, stated with the estimate: 35%); middle value at least 10-fold (1.00 log units) from the limit.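

In this assay compound 4 gives < 10 nM, which is a limit and not a number. Within the data shown here, the one readable comparison is an at least 1.5-fold lower number from compound 2 to compound 4 (0.17 log units; that floor lies within the scatter), so this aromatic carbon takes (morpholin-4-yl)carbonyl, with 0 hydrogen-bond donors, with no sign of a higher number. The other steps involving compound 4 cannot be read.

On these data alone, the true size of the gap between compound 2 and compound 4 stays open. Also open, as far as these compounds go, is whether the morpholine ring matters, or whether a piperidine or a dimethylamino group on the same carbonyl would serve equally well.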